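Iodo to cyclopropyl on the shared core

A few compounds are considered here, and "the series" means these few. Any claim that something is new, unique, unknown or untested is made for them only; others in the source may bear on it.

- compound 1 `N#Cc1cc(C(=O)N2CCc3ccccc32)ccc1O`: 3370 nM
- compound 2 `N#Cc1cc(C(=O)N2CCc3ccccc32)cc(I)c1O`: 15200 nM

In an ADME assay on the whole organism (Rattus norvegicus) for pharmacokinetics, read by HPLC, at a dose of 3 mg/kg by the oral route (on this read-out higher numbers stand for higher exposure at the dose given and lower numbers for lower exposure), compound 2 holds the higher of the two numbers, at 15200 nM. Compound 3 `N#Cc1cc(C(=O)N2CCc3ccccc32)cc(C2CC2)c1O` carries cyclopropyl in place of iodo on an aromatic carbon, ortho to a hydroxy group (cyclopropyl in place of iodo on an aromatic carbon). Among the compounds with values here, one measured step bears on this change: a 4.5-fold higher number from compound 1 to compound 2 (0.65 log units; beyond the scatter), where iodo took the place of hydrogen. Within the data shown here, no measured compound carries cyclopropyl, so the evidence is thin. A lower number is expected, though not a full return to the level of compound 1 at 3370 nM. The expected step, no larger than the measured one, is a 1.9-fold lower number from compound 2 to compound 3 (0.28 log units; within the scatter). For compound 3, the estimated value is 8000 nM, with an expected range of 3500 nM to 18000 nM.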

Compound 3, maximal plasma concentration: 4470 nM
Estimate against measurement, compound 3: 1.8-fold (0.25 log units) above; the measured number falls inside the stated range.
By their numbers in this assay, from the lowest: compounds 1 and 3 (each within the scatter of the next); then compound 2.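

In this assay, the higher number brought by iodo does not carry over to cyclopropyl on this aromatic carbon, ortho to a hydroxy group, with a 3.4-fold lower number from compound 2 to compound 3 (0.53 log units; beyond the scatter) on that exchange. Cyclopropyl in place of hydrogen gives a 1.3-fold higher number from compound 1 to compound 3 (0.12 log units; within the scatter) as its step, so compound 1 and compound 3 cannot be told apart on this read-out, and of these three compounds only compound 2, with iodo, stands clear of the others. Nothing available explains why iodo and cyclopropyl part here.

The compounds shown leave open whether the higher number is peculiar to iodo or extends to chloro, bromo or an amine on the same aromatic carbon. Also open, going by these compounds, is whether the step from iodo to cyclopropyl would hold on a different core.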